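The source may hold more compounds than are shown below. What is called first, only, known or untested is meant among the compounds shown, and "the series" means these compounds.

Four compounds share one core and differ in the group carried on an amide-type nitrogen, while compound 2 also has a core lacking one fluorine. Compound 1 `C#CCn1cc(C(=O)NC(CC(=O)NC2CCCCC2)c2ccccc2)c(=O)c2cc(F)c(Cl)nc21` carries a cyclohexyl group there, compound 2 `C#CCn1cc(C(=O)NC(CC(=O)NC2CCCC2)c2ccccc2)c(=O)c2ccc(Cl)nc21` a cyclopentyl group, compound 3 `C#CCn1cc(C(=O)NC(CC(=O)Nc2ccccn2)c2ccccc2)c(=O)c2cc(F)c(Cl)nc21` a pyridin-2-yl group, and compound 4 `C#CCn1cc(C(=O)NC(CC(=O)NC2CCCC2)c2ccccc2)c(=O)c2cc(F)c(Cl)nc21` a cyclopentyl group on the fluorinated core. In a functional assay on A549 cells (Homo sapiens) for cytotoxicity, read by MTT assay, with a stated time of 72 h (on this read-out lower numbers stand for stronger inhibition and higher numbers for weaker inhibition), compound 1 reaches only the limit of the assay, > 10000 nM. Compound 2 gives a number in this assay, 9500 nM. Compound 3 also reaches only the limit in this assay, > 10000 nM. Compound 3 thus stands at the limit of > 10000 nM in this assay, at which 2 of the 3 values shown sit. Compound 4 remains to be measured in this assay.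

The change from compound 3 to compound 4 is cyclopentyl in place of pyridin-2-yl on an amide-type nitrogen. Among the compounds with values here, only one measured step touches the same amide-type nitrogen: a step that the two limits leave unreadable from compound 1 to compound 3, and because both of its ends sit at the limit of > 10000 nM in this assay, at which 2 of the 3 values shown sit, its size cannot be read. Compound 2, which carries the same cyclopentyl group on the core lacking the fluorine, shows 9500 nM. The expected step that the limit leaves unreadable from compound 3 to compound 4 is therefore none beyond the scatter, with a fair chance that only a limit is reported again. Compound 4 is estimated at 12000 nM, within 5000 nM to 30000 nM.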

Compound 4, half-maximal inhibitory concentration: 6100 nM
For compound 4 the middle estimate is 2.0-fold (0.29 log units) above the measured one; measured number inside the range.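

Compound 4 gives the fluorinated core its first real number in this assay, so changes of the ring on this amide-type nitrogen now have a readable floor: going from pyridin-2-yl to cyclopentyl gives an at least 1.6-fold lower number from compound 3 to compound 4 (0.21 log units; that floor lies within the scatter), and going from cyclohexyl to cyclopentyl gives an at least 1.6-fold lower number from compound 1 to compound 4 (0.21 log units; that floor lies within the scatter). The true size of these two steps cannot be read, nor can the step between the pyridin-2-yl and cyclohexyl compounds, since those two compounds report only a limit of the assay and not a number: the limit of > 10000 nM in this assay, at which 2 of the 4 values shown sit.

With the cyclopentyl group held fixed, placing fluoro in place of hydrogen on an aromatic carbon gives a 1.6-fold lower number from compound 2 to compound 4 (0.19 log units; within the scatter), so in this assay the two cyclopentyl compounds cannot be told apart.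

No step shown here clearly goes beyond the usual scatter, so it remains open whether the cyclopentyl group truly differs from the cyclohexyl and pyridin-2-yl groups. Also open, going by these compounds, is what a longer open chain, or a ring carrying an amine or a carboxylic acid, would do on this amide-type nitrogen.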